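The source may report more compounds than this note shows. Statements on the series, on what has been measured and on what is new or still open speak of the compounds shown alone.

Measured compounds:
- compound 1, `CN(Cc1ccccc1)CC1CCN(CCCc2c[nH]c3ccc(-n4cnnc4)cc23)CC1`: 93%
- compound 2, `NC(=O)OC[C@H](NC1CCN(CCCc2c[nH]c3ccc(-n4cnnc4)cc23)CC1)c1ccccc1`: 73%
- compound 3, `OC[C@H](NC1CCN(CCCc2c[nH]c3ccc(Cn4cncn4)cc23)CC1)c1ccccc1`: 76%

All three share a core and were tested in a functional assay on CHO cells for activation of 5-hydroxytryptamine receptor 1D (Homo sapiens), read by GTPgammaS binding; on this read-out higher numbers stand for larger maximal responses and lower numbers for smaller maximal responses. Compound 1 reaches the highest of the three values, with 93%. The nearest is compound 3, whose 76% lies beyond the usual scatter below it, and the furthest is compound 2, whose 73% is lower still. Both of these lower compounds carry an amine attached straight to a saturated ring carbon, whereas compound 1 holds its amine one carbon further out.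

Compound 4, `CN(Cc1cccs1)C1CCN(CCCc2c[nH]c3ccc(-n4cnnc4)cc23)CC1`, has not yet been measured. It differs from compound 1 in a single place: methyl((thiophen-2-yl)methyl)amino in place of (benzyl(methyl)amino)methyl on a saturated ring carbon. The amine therefore now sits directly on the saturated ring carbon, as it does in compound 2 and compound 3, and the aromatic ring at its far end changes from a six-membered carbon ring to a five-membered ring with one sulfur.

For the measured compounds named here, no measured pair shows the effect of exactly this change, so the expectation rests on the three values alone. A modest step down, a number 9 percentage points lower from compound 1 to compound 4 (within the scatter), is expected from compound 1 to compound 4 in this assay, because compound 2 with 73% and compound 3 with 76% both carry a directly attached amine and both fall short of compound 1. Compound 4 is thus estimated at 84%, with a range from 68% to 100%.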

Compound 4, largest response reached (reported as efficacy), in percent of the reference or control that the assay uses: 81%
For compound 4 the middle estimate is 3 percentage points above the measured one, and the stated range covers the measured number.
By their numbers in this assay, from the lowest: compounds 2, 3 and 4 (each within the scatter of the next); then compound 1.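

In this assay putting methyl((thiophen-2-yl)methyl)amino in place of (benzyl(methyl)amino)methyl on a saturated ring carbon gives a number 12 percentage points lower from compound 1 to compound 4 (beyond the scatter) and so costs a real but modest part of the maximal response, while compound 4 at 81% still keeps most of what compound 1 reaches. For the compounds shown here, this is the first step in the set that changes only this one place, yet it bundles two changes: the amine now sits directly on the saturated ring carbon, and the six-membered aromatic ring of carbon gives way to a five-membered aromatic ring with one sulfur, so the step measures both together. Nothing at hand explains why the response falls.

Which of the two changes carries the step stays open, and benzyl(methyl)amino on the same saturated ring carbon would separate them by moving the amine while keeping the six-membered ring. Also open, going by these compounds, is how the response would follow other rings at the far end of the amine, such as furan or pyridine, or a longer chain leading to them.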